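A few compounds are considered here, and "the series" means these few. Any claim that something is new, unique, unknown or untested is made for them only; others in the source may bear on it.

Compound 1 `Cn1cc(-c2cnc3ccc(NCc4ccc(F)cc4)nc3c2)cn1` and compound 3 `Cn1cc(-c2cnc3ccnc(NCc4ccc(F)cc4)c3c2)cn1` have the same atoms joined differently; the difference between the two cores is not broken down here. In a functional assay on HeLa cells (Homo sapiens) for antiproliferative activity, read by MTT assay, with a stated time of 48 h (a higher number here means a weaker inhibitor, a lower number a stronger inhibitor), compound 1 gives 46600 nM. In this assay compound 3 gives 9200 nM, the lowest of the two numbers. Compound 2 `COc1ccc(CNc2ccc3ncc(-c4cnn(C)c4)cc3n2)cc1` carries the change methoxy in place of fluoro on an aromatic carbon on the core of compound 1. For compound 2 the result is a limit of the assay, > 50000 nM. The step of an at least 1.0-fold higher number from compound 1 to compound 2 (0.03 log units; that floor lies within the scatter) therefore rests on (the limit of > 50000 nM in this assay, at which 1 of the 3 values shown sits). Compound 4 `COc1ccc(CNc2nccc3ncc(-c4cnn(C)c4)cc23)cc1` carries the same change on the core of compound 3, (methoxy in place of fluoro on an aromatic carbon), at a place described in the same words. For compound 4 a step in the same direction is expected, a 2.2-fold higher number from compound 3 to compound 4 (0.34 log units; beyond the scatter), resting on the step of an at least 1.0-fold higher number from compound 1 to compound 2 (0.03 log units; that floor lies within the scatter). Compound 4 is estimated at 20000 nM, within 8000 nM and 50000 nM.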

Compound 4, half-maximal inhibitory concentration: 42200 nM
The estimate for compound 4 lay 2.1-fold (0.32 log units) below the measured number; low and high end bracket the measured number.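

In this assay, going from 4-fluorophenyl to 4-methoxyphenyl on the core of compound 3 gives a 4.6-fold higher number from compound 3 to compound 4 (0.66 log units; beyond the scatter), so on this core the change costs activity. Carrying that size over to the core of compound 1 is not supported, and neither is calling the two steps different: the same change on two cores in this assay, an at least 1.0-fold higher number (0.03 log units; that floor lies within the scatter) from compound 1 to compound 2 and a 4.6-fold higher number (0.66 log units; beyond the scatter) from compound 3 to compound 4; the limit leaves it open whether they differ

The step on that core ends in a limit of the assay for compound 2, not a number: the limit of > 50000 nM in this assay, at which 1 of the 4 values shown sits.

From the compounds shown here alone, only fluoro and methoxy appear at this place, so the reading for an amine, a carboxylic acid or a longer chain there remains open. Also open, going by these compounds, is whether any such group would behave alike on both cores.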